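Trimming the Amide Side Chain of Compound 2

The source may hold more compounds than are shown below. What is called first, only, known or untested is meant among the compounds shown, and "the series" means these compounds.

In an ADME assay on microsomes from liver (Homo sapiens) for metabolic stability, using NADPH, with a stated time of 40 min, tested at 2 uM (a higher number here means that the compound lasts longer, a lower number that the compound disappears faster), compound 1 (`Cc1ccc2c(-c3ccc4ccccc4n3)c[nH]c2c1F`) gives 0.25 h and compound 2 (`CC(C)NC(=O)c1cccc2nc(-c3c[nH]c4c(F)c(F)c(F)cc34)ccc12`) gives 3.43 h as the higher of the two numbers. Compound 3 (`CNC(=O)c1cccc2nc(-c3c[nH]c4c(F)c(F)c(F)cc34)ccc12`) departs from compound 2 in one place, with methyl in place of isopropyl on an amide-type nitrogen. Within the data shown here, no measured pair shows this change on its own, so the data offer no direct guide. The expected step (a 1.0-fold higher number from compound 2 to compound 3 (0.01 log units; within the scatter)) is none beyond the usual scatter, with no firm direction. For compound 3 the expected half-life is 3.5 h with an estimated range of 1.5 h to 8 h around it.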

Compound 3, half-life: 1.17 h
Compound 3: the middle estimate sits 3.0-fold (0.48 log units) above what was measured; the measured number lies below the stated range.
By their numbers in this assay, from the lowest: compound 1; then compound 3; then compound 2.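

Swapping isopropyl for methyl on the amide-type nitrogen is not a neutral change: in this assay it gives a 2.9-fold lower number from compound 2 to compound 3 (0.47 log units; beyond the scatter) in half-life. Among these compounds, this is the first direct reading at this position, and it shows that the side chain alone, with the shared core unchanged, can move the number beyond the scatter. Nothing available explains why the half-life drops. Going by these compounds, whether ethyl would land between methyl and isopropyl remains open. So does the effect of a larger tert-butyl group or a longer chain ending in an amine.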